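The source may hold more compounds than are shown below. What is called first, only, known or untested is meant among the compounds shown, and "the series" means these compounds.

Measured so far:
compound 1, `Cc1cc(O)c(C2=NN(c3ccc(S(N)(=O)=O)cc3)C(c3ccccc3O)C2)cc1Cl`, 64800 nM
compound 2, `Cc1cc(O)c(C2=NN(c3ccc(S(N)(=O)=O)cc3)C(/C=C/c3ccccc3)C2)cc1Cl`, 52600 nM

Both compounds were tested in a functional assay on RXF 393 cells (Homo sapiens) for antiproliferative activity, with a stated time of 48 h; a lower number here means that less compound is tolerated, a higher number that more compound is tolerated. Compound 1 gives 64800 nM, and compound 2 gives 52600 nM. Going by the values given here, the only step between them, a 1.2-fold lower number from compound 1 to compound 2 (0.09 log units; within the scatter), involved swapping the group on a saturated ring carbon of the shared core, and it left the read-out essentially unchanged. On the two numbers at hand, compound 2 is therefore not set apart from compound 1.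

Compound 3, `COc1ccc(C2CC(c3cc(Cl)c(C)cc3O)=NN2c2ccc(S(N)(=O)=O)cc2)c(OC)c1OC`, has not yet been measured. It differs from compound 2 at the same saturated ring carbon: 2,3,4-trimethoxyphenyl in place of 2-phenylethenyl on a saturated ring carbon. Among the compounds with values here, the one measured step that bears on this position, a 1.2-fold lower number from compound 1 to compound 2 (0.09 log units; within the scatter), was within the scatter even though it exchanged an aromatic ring for a 2-phenylethenyl group. Within the data shown here, only a single step is available, so the expectation rests on it alone. Compound 3 is expected to show no step beyond the scatter, with a 1.1-fold lower number from compound 2 to compound 3 (0.02 log units; within the scatter). The estimate for compound 3 in this assay is 50000 nM, within a range from 22000 nM to 110000 nM.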

Compound 3, concentration lethal to 50% of the cells: 20000 nM
Estimate against measurement, compound 3: 2.5-fold (0.40 log units) above, and the stated range ends above it.
By their numbers in this assay, from the lowest: compound 3; then compounds 2 and 1 (each within the scatter of the next).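

The saturated ring carbon of the shared core is not indifferent to what it carries in this assay: the earlier exchange gave only a 1.2-fold lower number from compound 1 to compound 2 (0.09 log units; within the scatter), whereas the 2,3,4-trimethoxyphenyl group gives a 2.6-fold lower number from compound 2 to compound 3 (0.42 log units; beyond the scatter) and also a 3.2-fold lower number from compound 1 to compound 3 (0.51 log units; beyond the scatter). Both new steps are modest, but they lie beyond the scatter and run in the same direction, so this group separates compound 3 from both earlier compounds, while those two remain within the scatter of each other. Compared with 2-phenylethenyl, the entering group keeps one six-membered aromatic ring, has 12 heavy atoms rather than 8, and counts 3 hydrogen-bond acceptors rather than 0, yet no measurement shown here explains the lower number.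

The three compounds cannot show whether all the methoxy groups are needed, or whether a phenyl ring with a single methoxy group would give a similar number. Nor do they show how this position would respond to a group of a different kind, such as an amine or a carboxylic acid.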